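Phenethyl for 3,5-dimethylphenyl on sulfur: working notes

A few compounds are considered here, and "the series" means these few. Any claim that something is new, unique, unknown or untested is made for them only; others in the source may bear on it.

In a functional assay on HCT-116 cells (Homo sapiens) for inhibition, read by CCK-8 assay, with a stated time of 72 h, tested at 2 uM (a lower number here means less inhibition of growth, a higher number more inhibition of growth at the concentration tested), compound 1 (`Cc1cc(C)cc(SCc2ccc(/C=C/C(=O)Nc3ccccc3N)cc2)c1`) gives 7.98% and compound 2 (`Nc1ccccc1NC(=O)c1ccc(CSc2ccc(Br)cc2)cc1`) gives 9.96% which places the two within the scatter of each other. Compound 3 (`Nc1ccccc1NC(=O)c1ccc(CSc2nccc(C(F)(F)F)n2)cc1`) gives 82.7% which lies far higher and beyond the scatter of both. Compound 4 (`Nc1ccccc1NC(=O)/C=C/c1ccc(CSCCc2ccccc2)cc1`) carries phenethyl in place of 3,5-dimethylphenyl on a sulfur and otherwise matches compound 1. Among the compounds with values here, no measured step isolates this change, so the expectation rests on compound 1 (7.98%) and no shift beyond the scatter is expected. The estimated step is a small rise (a number 6 percentage points higher from compound 1 to compound 4 (within the scatter)) in this assay for now. For compound 4 the estimated value is 14% with an expected range (3% to 40%).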

Compound 4, percent growth inhibition at one concentration: 18%
Compound 4: the middle estimate sits 4 percentage points below what was measured; the range from low to high includes it.
By their numbers in this assay, from the lowest: compounds 1, 2 and 4 (each within the scatter of the next); then compound 3.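

In this assay, phenethyl in place of 3,5-dimethylphenyl on the sulfur gives a number 10 percentage points higher from compound 1 to compound 4 (within the scatter) on the core of compound 1. The two groups have the same heavy-atom count and one aromatic ring each, yet differ in how that ring is joined to the sulfur, and at this single test concentration the assay does not tell compound 1 and compound 4 apart. From the compounds shown here alone, how benzyl or a longer chain such as phenylpropyl on this sulfur would read in this assay stays open. No measurement available here bears on a cause for this step.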